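Chain length on the aromatic nitrogen: outlook for compound 4

The source may report more compounds than this note shows. Statements on the series, on what has been measured and on what is new or still open speak of the compounds shown alone.

Compound 1 `CCn1c(/C=C2/C(=O)Nc3ccc(F)cc32)nc2ccccc21` carries an ethyl group on the aromatic nitrogen; in a functional assay on 4T1 cells (Homo sapiens) for cytotoxicity, read by MTT assay, with a stated time of 48 h (on this read-out higher numbers stand for weaker inhibition and lower numbers for stronger inhibition), compound 1 reaches only a limit of the assay, > 50000 nM. Compound 2 `CC(C)n1c(/C=C2/C(=O)Nc3ccc(F)cc32)nc2ccccc21` differs by methyl in place of hydrogen on a saturated chain carbon bound to an aromatic nitrogen and a saturated chain carbon and in this assay compound 2 gives 25800 nM, a step of an at least 1.9-fold lower number from compound 1 to compound 2 (0.28 log units; that floor lies within the scatter). Compound 3 `Cn1c(/C=C2/C(=O)Nc3ccc(Cl)cc32)nc2ccccc21` gives 43600 nM; the difference between the cores of compound 1 and compound 3 is not broken down here. Compound 4 `CCn1c(/C=C2/C(=O)Nc3ccc(Cl)cc32)nc2ccccc21` differs from compound 3 by methyl in place of hydrogen on a saturated chain carbon bound to an aromatic nitrogen. The place differs in its words, a saturated chain carbon bound to an aromatic nitrogen rather than one bound also to a saturated chain carbon, so this is the same kind of change, not the same. A step of a 1.5-fold lower number from compound 3 to compound 4 (0.16 log units; within the scatter) is expected because the earlier change gave an at least 1.9-fold lower number from compound 1 to compound 2 (0.28 log units; that floor lies within the scatter). Compound 4 is estimated at 30000 nM, between 12000 nM and 60000 nM.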

Compound 4, half-maximal inhibitory concentration: > 50000 nM
Compound 4 gave a limit, no number; the forecaster's own chance of this, stated with the estimate: 25%; middle value at least 1.6-fold (0.22 log units) from the limit.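

Carrying the change to the core of compound 3 gives an at least 1.1-fold higher number from compound 3 to compound 4 (0.05 log units; that floor lies within the scatter), which is a floor and not a measured size. This shows neither that the change carries over between cores nor that it fails to: the same change on two cores in this assay, an at least 1.9-fold lower number (0.28 log units; that floor lies within the scatter) from compound 1 to compound 2 and an at least 1.1-fold higher number (0.05 log units; that floor lies within the scatter) from compound 3 to compound 4; the limit leaves it open whether they differ. The step between the chloro and fluoro compounds, compound 1 and compound 4, cannot be read, and the limit restricts what this part of the series can show: the limit of > 50000 nM in this assay, at which 2 of the 4 values shown sit.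

The compounds shown leave open how a longer chain, such as butyl, on the aromatic nitrogen would read on either core. On these data alone, it also remains open whether isopropyl on the core of compound 3 would give a number rather than a limit.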